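Chloro to bromo on a core that tolerates both

This account rests on a few compounds, and the source may have more. Where it says the series, first, only, none or still open, it means among the compounds named here.

Compound 2 `Cc1ncnc2c1c(Cl)cn2[C@@H]1C=C(CO)[C@@H](O)[C@H]1O` carries chloro on an aromatic carbon of the shared core. In an ADME assay on Huh-7 cells (Homo sapiens) for cytotoxicity (a lower number here means that less compound is tolerated, a higher number that more compound is tolerated), compound 2 gives only a limit, > 100000 nM. Compound 1 `Cc1ncnc2c1ccn2[C@@H]1C=C(CO)[C@@H](O)[C@H]1O` also reaches only a limit in this assay, > 100000 nM. The step that the two limits leave unreadable from compound 1 to compound 2 therefore cannot be read, since (the limit of > 100000 nM in this assay, at which 2 of the 2 values shown sit). Compound 3 `Cc1ncnc2c1c(Br)cn2[C@@H]1C=C(CO)[C@@H](O)[C@H]1O` differs from compound 2 by bromo in place of chloro on an aromatic carbon. Among the compounds with values here, no measured step bears on a swap of one halogen for another, and the one step available is unreadable, so compound 3 is expected to remain at the limit, with a number no higher from compound 2 to compound 3 (the limit leaves the size open) near zero. Compound 3 is estimated at 100000 nM, between 50000 nM and 200000 nM.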

Compound 3, half-maximal cytotoxic concentration: > 100000 nM
Compound 3 gave a limit, no number; the forecaster's own chance of this, stated with the estimate: 85%; the middle value sits exactly at the limit.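

No step among compound 1, compound 2 and compound 3 can be read in this assay, because each gives only a limit: the limit of > 100000 nM in this assay, at which 3 of the 3 values shown sit.

The compounds shown leave open whether chloro or bromo on the aromatic carbon changes the tolerated concentration at all.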